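From Ethoxy to Butoxy on a Shared Core

The source may report more compounds than this note shows. Statements on the series, on what has been measured and on what is new or still open speak of the compounds shown alone.

In a functional assay on the whole organism with Rattus norvegicus as the target (a lower number here means that less compound is needed, a higher number that more compound is needed for the effect), compound 1 `CCCCOC(=O)Oc1ccc(-c2ccc(F)cc2)cc1C(=O)O` gives 25 mg/kg and compound 2 `CCOC(=O)Oc1ccc(-c2ccc(F)cc2F)cc1C(=O)O` gives 30 mg/kg. These two numbers lie within the usual scatter of each other, and compound 2 stands level with compound 1.

Compound 3 `CCCCOC(=O)Oc1ccc(-c2ccc(F)cc2F)cc1C(=O)O` differs from compound 2 in one place: ethyl in place of hydrogen on a saturated chain carbon, two bonds along the chain from an oxygen next to a carbonyl group. Ethyl takes the place of a hydrogen on a saturated chain carbon, two bonds along the chain from an oxygen next to a carbonyl group, which turns ethoxy into butoxy.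

Among the compounds with values here, no measured pair of compounds shows this change on its own, and its effect in this assay remains open. No shift beyond the scatter is expected, in either direction. The estimated change is a 1.1-fold lower number from compound 2 to compound 3 (0.03 log units; within the scatter). Compound 3 is expected at 28 mg/kg, with an estimated range from 14 mg/kg to 55 mg/kg.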

Compound 3, dose for half-maximal effect: 12 mg/kg
Estimate against measurement, compound 3: 2.3-fold (0.37 log units) above, and the stated range ends above it.
By their numbers in this assay, from the lowest: compound 3; then compounds 1 and 2 (each within the scatter of the next).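

In this assay, this saturated chain position responds to its substituent: turning ethoxy into butoxy gives a 2.5-fold lower number from compound 2 to compound 3 (0.40 log units; beyond the scatter). The aromatic carbon matters too, since fluoro in place of hydrogen there gives a 2.1-fold lower number from compound 1 to compound 3 (0.32 log units; beyond the scatter). Both steps are modest but lie beyond the scatter, so each of these single changes shifts the dose needed on its own, and compound 3 carries both of them. Nothing shown here bears on the reason for either shift.

The compounds shown leave open whether a chain longer than butoxy, such as hexyloxy, or a branched one, such as isopropoxy, would lower the number further or raise it again. They also leave open whether ethoxy to butoxy would give a step of similar size on the core of compound 1.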